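Adding an Acetyl Group to a Weak Endothelin Binder

The source may report more compounds than this note shows. Statements on the series, on what has been measured and on what is new or still open speak of the compounds shown alone.

Of the compounds shown here, two have been measured in an assay on A10 cells for binding affinity to Endothelin-1 receptor (Rattus norvegicus); on this read-out lower numbers stand for stronger inhibition and higher numbers for weaker inhibition. Compound 1 `Cc1ccccc1C(CCC(=O)O)C(=O)c1cccc(OCc2ccsc2)c1` gives 110 nM in this assay. Compound 2 `Cc1ccccc1C(CCC(=O)O)Oc1cccc(OCc2ccsc2)c1` gives 871 nM, the higher of the two numbers, and its gap to compound 1 lies beyond the usual scatter, so compound 2 is the weaker binder of this pair.

Compound 3 `CC(=O)c1ccc(OCc2ccsc2)cc1OC(CCC(=O)O)c1ccccc1C` has not yet been measured. It differs from compound 2 in one place: acetyl in place of hydrogen on an aromatic carbon. Among the compounds with values here, no measured pair shows what this particular change does, so the expectation rests on the structural change alone. A modest step toward stronger binding is expected, shown as a 2.9-fold lower number from compound 2 to compound 3 (0.46 log units; beyond the scatter), although a result within the scatter would not be surprising. On that basis compound 3 is estimated to give 300 nM in this assay, with a plausible range from 60 nM to 1500 nM.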

Compound 3, half-maximal inhibitory concentration: 26 nM
For compound 3 the middle estimate is 12-fold (1.06 log units) above the measured one, and the stated range ends above it.
By their numbers in this assay, from the lowest: compound 3; then compound 1; then compound 2.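

In this assay, placing acetyl on this aromatic carbon, ortho to a large group and para to a (thiophen-3-yl)methoxy group, gives a 34-fold lower number from compound 2 to compound 3 (1.53 log units; beyond the scatter). This position therefore accepts a substituent, and here a small one of three heavy atoms, with no ring and no hydrogen-bond donor, goes with much stronger binding. Nothing measured here bears on how acetyl produces this gain.

From the compounds shown here alone, whether the gain is particular to acetyl remains open: a nitrile, a methyl ester or a longer chain such as propanoyl on the same carbon would help to show how specific it is. Going by these compounds, it is also open whether adding acetyl to compound 1 would bring a similarly large step, as this single pair speaks only for the core of compound 2.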